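The source may report more compounds than this note shows. Statements on the series, on what has been measured and on what is new or still open speak of the compounds shown alone.

Of the compounds shown here, two have been measured so far. Compound 1 `COc1ccc(/C=C/C[C@H]2C[C@@H]([C@@H](O)c3ccccc3)CO[C@@H]2c2ccccc2)cc1` gives, in a functional assay on HeLa cells (Homo sapiens) for cytotoxicity, read by WST assay, with a stated time of 48 h (on this read-out lower numbers stand for stronger inhibition and higher numbers for weaker inhibition), a value of 8300 nM. Compound 2 `CCCCCC/C=C/C[C@H]1C[C@@H]([C@@H](O)c2ccccc2)CO[C@@H]1c1ccccc1` gives in this assay a value of 7400 nM. Going by the values given here, compound 2 thus stands alongside compound 1, the only other measured compound, and the gap between them, a 1.1-fold lower number from compound 1 to compound 2 (0.05 log units; within the scatter), lies within the scatter: swapping 4-methoxyphenyl for hexyl on a double-bonded chain carbon bound to a double-bonded chain carbon left the read-out essentially unchanged.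

Compound 3 `O[C@@H](c1ccccc1)[C@H]1CO[C@H](c2ccccc2)[C@@H](C/C=C/c2ccccc2F)C1` is not yet measured. It differs from compound 2 at the same place: 2-fluorophenyl in place of hexyl on a double-bonded chain carbon bound to a double-bonded chain carbon

Among the compounds with values here, the only step that bears on this change is the one from compound 1 to compound 2, where an aromatic group and a hexyl chain at this position gave numbers within the scatter of each other. Since a substituted phenyl at this position in compound 1 gave 8300 nM, compound 3 is expected to sit in the same region, with an expected step of a 1.1-fold higher number from compound 2 to compound 3 (0.03 log units; within the scatter), that is, no change beyond the scatter. Compound 3 is therefore estimated at 8000 nM in this assay, with a range from 3500 nM to 18000 nM.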

Compound 3, half-maximal inhibitory concentration: 9730 nM
For compound 3 the middle estimate is 1.2-fold (0.09 log units) below the measured one; the range from low to high includes it.
By their numbers in this assay, from the lowest: compounds 2, 1 and 3 (each within the scatter of the next).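

Replacing hexyl with 2-fluorophenyl on a double-bonded chain carbon bound to a double-bonded chain carbon gives a 1.3-fold higher number from compound 2 to compound 3 (0.12 log units; within the scatter), and replacing 4-methoxyphenyl with 2-fluorophenyl gives a 1.2-fold higher number from compound 1 to compound 3 (0.07 log units; within the scatter), so both new steps in this assay stay within the scatter. The earlier pair set a single aromatic group against a single open chain, whereas the series now holds two differently substituted phenyl groups as well as the chain, and this read-out separates none of the three at this place. No evidence is available that would explain this lack of separation.

The compounds shown carry only carbon-rich groups at this place, apart from the methoxy oxygen and the fluorine, so it remains open whether an amine, a carboxylic acid, or a much longer chain would also leave the read-out unmoved. Going by these compounds, it also remains open whether changes elsewhere on the shared core, such as at the hydroxyl group or at either unsubstituted phenyl group, would shift the values more than this position has.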